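The source may hold more compounds than are shown below. What is called first, only, known or untested is meant among the compounds shown, and "the series" means these compounds.

Compound 1, `Cc1nc2sc(Nc3ccccc3)nc2c(=O)[nH]1`, is the starting point of this set. In an assay on CHO cells for displacement of a labelled ligand from adenosine receptor A1 (Homo sapiens), read by scintillation counting, with a stated time of 120 min, tested at 1 uM (on this read-out higher numbers stand for more inhibition at the one concentration tested (going by the name of the read-out) and lower numbers for less inhibition), compound 1 gives 24%. Compound 2, `COc1cccc(Nc2nc3c(=O)[nH]c(C)nc3s2)c1`, carries one extra group on the ring of compound 1, and in this assay compound 2 gives 8%. The change is methoxy in place of hydrogen on an aromatic carbon, and it made the step of a number 16 percentage points lower from compound 1 to compound 2 (beyond the scatter).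

Compound 3, `CCOc1nc(C)nc2sc(Nc3ccccc3)nc12`, rests on a different core; the difference between the two cores is not broken down here. In this assay compound 3 gives 2%, the lowest of the three numbers, though its value and that of compound 2 lie within the scatter of each other, while compound 1 stands well above it.

Compound 4, `CCOc1nc(C)nc2sc(Nc3cccc(OC)c3)nc12`, has not yet been measured. Among the compounds with values here, it differs from compound 3 by methoxy in place of hydrogen on an aromatic carbon, which is the same change as the one from compound 1 to compound 2, made at the same kind of place. From compound 3 to compound 4 the step is expected to be no change at the digits printed from compound 3 to compound 4 (within the scatter), set beside the earlier a number 16 percentage points lower from compound 1 to compound 2 (beyond the scatter): a drop of the earlier size cannot be repeated because compound 3 already sits at 2%, so the number is expected to stay low rather than fall further. For compound 4 the estimated value in this assay is 2%, expected between -6% and 10%.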

Compound 4, a percentage reported as inhibition, at one concentration (the size of the read-out at that concentration, not a potency): 3%
Beside the measured number, compound 4's estimate is 1 percentage points below it; measured number inside the range.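

In this assay, methoxy in place of hydrogen on an aromatic carbon gives a number 1 percentage points higher from compound 3 to compound 4 (within the scatter), so on the core of compound 3 the change has no effect that can be read. Set beside its result on the core of compound 1, the change does not carry over in size from one core to the other: the same change on two cores in this assay, a number 16 percentage points lower (beyond the scatter) from compound 1 to compound 2 and a number 1 percentage points higher (within the scatter) from compound 3 to compound 4, 17 percentage points apart, beyond the scatter of two such steps. This does not show that the two cores truly respond in different ways: compound 3 already gives 2%, which leaves little room for a drop of the earlier size to appear, and the comparison rests on a single pair per core, read at one concentration and not as a potency.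

The compounds shown leave open whether any other group on this ring, such as chlorine, an amine or a carboxylic acid, would raise the number on either core, and whether a longer chain in place of methoxy would behave as methoxy does. They also leave open whether methoxy placed elsewhere on the ring would give the same result, and whether the gap between the two steps would hold for a pair on the core of compound 3 with a higher starting number.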